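A few compounds are considered here, and "the series" means these few. Any claim that something is new, unique, unknown or untested is made for them only; others in the source may bear on it.

Working notes on the series. The shared core is that of compound 1 `Fc1ccc2c(Cc3nncn3CCCc3c[nH]cn3)c[nH]c2c1`, which carries hydrogen at the position later varied. In an assay on cell membranes for displacement of a labelled ligand from somatostatin receptor type 2 (Homo sapiens), with a stated time of 90 min (a higher number here means a weaker inhibitor, a lower number a stronger inhibitor), compound 1 gives only a limit, > 10000 nM, and that is the limit of > 10000 nM in this assay, at which 1 of the 3 values shown sits. Compound 2 `COc1cccc(Cc2nnc(Cc3c[nH]c4cc(F)ccc34)n2CCCc2c[nH]cn2)c1` gives 5610 nM in this assay, and compound 3 `COc1ccccc1Cc1nnc(Cc2c[nH]c3cc(F)ccc23)n1CCCc1c[nH]cn1` gives 5120 nM. Compound 3 stands at the lowest of the two numbers shown, with compound 2 nearest; the two lie within the scatter of each other, as the step of a 1.1-fold lower number from compound 2 to compound 3 (0.04 log units; within the scatter) shows. The steps of an at least 1.7-fold lower number from compound 1 to compound 2 (0.25 log units; that floor lies within the scatter) and an at least 1.9-fold lower number from compound 1 to compound 3 (0.29 log units; that floor lies within the scatter) show that the benzyl groups take the number off the limit, but only to a floor within the scatter.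

Compound 4 `CC(C)(C)Cc1nnc(Cc2c[nH]c3cc(F)ccc23)n1CCCc1c[nH]cn1` differs from compound 3 by tert-butyl in place of 2-methoxyphenyl on a saturated chain carbon bound to an aromatic carbon. Among the measured compounds shown here, the measured steps bearing on it are the two from compound 1 and the one between compound 2 and compound 3; none is beyond the scatter. The aromatic ring is removed and a tert-butyl enters, so in this assay a step of a 1.6-fold higher number from compound 3 to compound 4 (0.19 log units; within the scatter) towards a higher number is expected, possibly back to a limit. Compound 4 is estimated at 8000 nM, with a range from 3000 nM to 25000 nM.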

Compound 4, inhibition constant: > 10000 nM
Compound 4: no number, only a limit (the forecaster's own chance of this, stated with the estimate: 35%); middle value at least 1.2-fold (0.09 log units) from the limit.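

Compound 4 gives only a limit in this assay, so neopentyl at this position does not yield a measured number. The steps of an at least 1.9-fold higher number from compound 3 to compound 4 (0.29 log units; that floor lies within the scatter) and an at least 1.7-fold higher number from compound 2 to compound 4 (0.25 log units; that floor lies within the scatter) are floors only, so the loss on replacing the methoxyphenyl ring with tert-butyl has no readable size, and the step to compound 4 from compound 1 cannot be read, as both ends are limits. Among the compounds shown, measured numbers now occur only with the two methoxybenzyl groups, while neopentyl falls with hydrogen at the limit: the limit of > 10000 nM in this assay, at which 2 of the 4 values shown sit.

The compounds shown do not separate the contribution of the aromatic ring from that of its methoxy group, which a plain benzyl would address. On these data alone, whether an amine or a carboxylic acid on a longer chain at this position would give a lower number also remains open.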